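This account rests on a few compounds, and the source may have more. Where it says the series, first, only, none or still open, it means among the compounds named here.

Measured in a physicochemical assay for solubility, at pH 7.4; on this read-out higher numbers stand for higher solubility and lower numbers for lower solubility:
- compound 1 `Cc1c2c(n3c1CCCNC[C@H](C)Nc1cc-3ccc1C(N)=O)CC(C)(C)CC2=O` gives > 100 ug/mL (a limit)
- compound 2 `CC[C@H](N)C(=O)N1CCc2c(C)c3c(n2-c2ccc(C(N)=O)c(c2)N[C@@H](C)[C@H](C)C1)CC(C)(C)CC3=O` gives > 100 ug/mL (a limit)

Compound 2 stands at the limit of > 100 ug/mL in this assay, at which 2 of the 2 values shown sit, and so has a limit, not a number. Compound 3 `Cc1c2c(n3c1CCN(C(=O)C(C)(C)N)C[C@@H](C)[C@H](C)Nc1cc-3ccc1C(N)=O)CC(C)(C)CC2=O` carries 1-amino-1-methylethyl in place of 1-aminopropyl on a carbonyl carbon, a change counted as 1-amino-1-methylethyl in place of 1-aminopropyl on a carbonyl carbon (the same atoms, joined differently). Going by the values given here, no measured pair shows this change, and no step beyond the scatter is expected in this assay in either direction. The estimate means a step that the limit leaves unreadable from compound 2 to compound 3 inside the usual scatter. For compound 3 the estimated value is 110 ug/mL with an expected range from 50 ug/mL to 200 ug/mL and may again come back as a limit.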

Compound 3, solubility: > 100 ug/mL
Compound 3: only a limit was reported; the forecaster's own chance of this, stated with the estimate: 75%; the middle value does not contradict the limit.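

No step can be read from compound 2 to compound 3, because both give only a limit in this assay: the limit of > 100 ug/mL in this assay, at which 3 of the 3 values shown sit.

The compounds shown leave open whether 1-amino-1-methylethyl in place of 1-aminopropyl on a carbonyl carbon changes this read-out at all.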